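Swapping an alkene linker for an alkyne: lipophilicity

The compounds below may be only part of what the source reports. "The series", "measured", "known", "first", "only" and "open" are said of these compounds alone.

Four compounds share the theme of a phenyl-bearing unsaturated linker attached to a carbonyl carbon. Compound 1 `O=C(COC(=O)/C=C/c1ccccc1)NCCC[Te]c1ccccc1` carries a tellurium-containing chain, and in a physicochemical assay for lipophilicity, read by HPLC, measured as octanol-water partition (on this read-out lower numbers stand for lower lipophilicity and higher numbers for higher lipophilicity), compound 1 gives 3.01. Compound 2 `COc1ccc(N(CC(=O)NCCC[Se]c2ccccc2)C(=O)/C=C/c2ccccc2)cc1` and compound 3 `COc1ccc(N(CC(=O)NCCC[Se]c2ccccc2)C(=O)C#Cc2ccccc2)cc1` carry a selenium-containing chain on a different core; the difference between the two cores is not broken down here. In this assay compound 2 gives 3.7 and compound 3 gives 2.6. Among the measured compounds shown here, the only change between them is 2-phenylethynyl in place of 2-phenylethenyl on a carbonyl carbon, and it gave a number 1.10 log units lower from compound 2 to compound 3 (beyond the scatter). Compound 4 `O=C(COC(=O)C#Cc1ccccc1)NCCC[Te]c1ccccc1` has not yet been measured. It differs from compound 1 by 2-phenylethynyl in place of 2-phenylethenyl on a carbonyl carbon. This is the same kind of change as that from compound 2 to compound 3, but the place is not identical: in compound 2 the carbonyl carbon also bears an amide-type nitrogen, whereas in compound 1 it bears an oxygen next to a carbonyl group. Because of a number 1.10 log units lower from compound 2 to compound 3 (beyond the scatter) a comparable drop is expected, namely a number 1.01 log units lower from compound 1 to compound 4 (beyond the scatter). For compound 4 the estimate is 2, lying between 1.5 and 2.6.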

Compound 4, partition coefficient: 0.9
Compound 4: middle estimate off by 1.10 log units, on the high side; the measured number lies below the stated range.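

In this assay, the swap to 2-phenylethynyl in place of 2-phenylethenyl gave a number 2.11 log units lower from compound 1 to compound 4 (beyond the scatter), compared with a number 1.10 log units lower from compound 2 to compound 3 (beyond the scatter) on the other core, so the direction carried over across these two pairs while the size did not. Two pairs show only that the drop appeared on both cores, and they do not show that a step measured on one core can be moved to another at the same size. The two cores differ in the other neighbour of the carbonyl carbon, in the rest of the core and in whether the chain holds tellurium or selenium, and no measurement here explains the larger step or ties it to any one of these differences.

The compounds shown leave open how a 2-phenylethyl group, with neither a double nor a triple bond outside the ring, would compare on either core. They also leave open whether the same drop would appear on a core whose chain holds sulfur.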